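A few compounds are considered here, and "the series" means these few. Any claim that something is new, unique, unknown or untested is made for them only; others in the source may bear on it.

Working notes on the series.

Of the compounds shown here, two of this set have been measured in a functional assay on MDA-MB-231 cells (Homo sapiens) for cytotoxicity, read by sulforhodamine B assay, with a stated time of 48 h; on this read-out higher numbers stand for lower toxicity in this test and lower numbers for higher toxicity in this test. Compound 1 `ClCc1cccc(Cn2cnc3ncnc(Cl)c32)c1` gives 6760 nM in this assay. Compound 2 `ClCc1ccc(Cn2cnc3c(Cl)nc(Cl)nc32)cc1` gives 7240 nM in this assay. Compound 1 carries the lowest of the two numbers, but compound 2 stands only a little apart from it and the two values lie within the scatter of each other, so nothing can be said about an order between them.

Compound 3 `ClCc1cccc(Cn2cnc3nc(Cl)nc(Cl)c32)c1` has not yet been measured in this assay. It differs from compound 1 in one place: chloro in place of hydrogen on an aromatic carbon. Within the data shown here, no directly comparable pair among the measured compounds isolates this change, so no measured step is available for it. The two measured values show that a core bearing two chloro groups, in compound 2, and a core bearing one chloro group, in compound 1, sit within the scatter of each other, although the benzyl substitution pattern also differs between those two compounds. On this basis the step of a 1.0-fold higher number from compound 1 to compound 3 (0.02 log units; within the scatter) is expected to stay within the scatter, with no clear direction. Compound 3 is therefore estimated at 7000 nM in this assay, with a range from 3500 nM to 14000 nM.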

Compound 3, concentration lethal to 50% of the cells: 4160 nM
Estimate against measurement, compound 3: 1.7-fold (0.23 log units) above; measured number inside the range.
By their numbers in this assay, from the lowest: compounds 3, 1 and 2 (each within the scatter of the next).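

In this assay, among these compounds, chloro in place of hydrogen on an aromatic carbon between two ring nitrogen atoms gives a 1.6-fold lower number from compound 1 to compound 3 (0.21 log units; within the scatter), the first step read at this position with the rest of the structure held the same. The earlier compounds shown here could not show this, as compound 1 and compound 2 differ in more than one place; this single change now shows that a chloro group at this position leaves the number within the scatter of that of the hydrogen compound, and so gives no clear direction. No measured information on any property of these compounds bears on this result.

From the compounds shown here alone, only hydrogen and chloro have been compared at this position, so it remains open whether another group there, such as an amine, a methoxy group or a longer carbon chain, would give a step beyond the scatter. The compounds shown also leave open whether the same change would give a similar step on the benzyl substitution pattern of compound 2, and whether it would do so in any other test.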